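A few compounds are considered here, and "the series" means these few. Any claim that something is new, unique, unknown or untested is made for them only; others in the source may bear on it.

Compound 1 `COc1cc(N(Cc2ccc(Br)cc2)C(=O)CSc2nc3ccccc3s2)cc(OC)c1OC` stands highest of the two numbers shown: in a functional assay on HCT-116 cells (Homo sapiens) for antiproliferative activity, read by MTT assay, with a stated time of 48 h (on this read-out lower numbers stand for stronger inhibition and higher numbers for weaker inhibition), compound 1 gives 63800 nM, while compound 2 `COc1ccc(CN(C(=O)CSc2nc3c(C)cccc3s2)c2cc(OC)c(OC)c(OC)c2)cc1O` gives 852 nM, a lower number that lies beyond the scatter. Compound 3 `COc1cc(N(Cc2ccc(Cl)cc2)C(=O)CSc2nc3ccccc3s2)cc(OC)c1OC` differs from compound 1 only by chloro in place of bromo on an aromatic carbon. Among the measured compounds shown here, no measured pair here shows this single change, so its effect is not known from the data. The step of a 1.1-fold higher number from compound 1 to compound 3 (0.04 log units; within the scatter) is expected to be small, with no direction beyond the scatter. Compound 3 is therefore estimated at 70000 nM, within a range of 25000 nM to 200000 nM.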

Compound 3, half-maximal inhibitory concentration: 603000 nM
The estimate for compound 3 lay 8.6-fold (0.94 log units) below the measured number, outside the stated range (above it).
By their numbers in this assay, from the lowest: compound 2; then compound 1; then compound 3.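

In this assay, chloro in place of bromo on an aromatic carbon gives a 9.5-fold higher number from compound 1 to compound 3 (0.98 log units; beyond the scatter), so this site, para to a large group, responds to the exchange of a single halogen atom. The change alters no ring, hydrogen-bond donor or acceptor count, or net charge. Nothing available here accounts for the size of this step. The compounds shown leave open how fluoro or an amine would read at this site. They also leave open whether the same exchange would give a similar step in compound 2, which differs from compound 1 in more than one place.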